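The source may hold more compounds than are shown below. What is called first, only, known or untested is meant among the compounds shown, and "the series" means these compounds.

Measured compounds:
- compound 1, `Cc1cccc(NNS(=O)(=O)c2ccc(S(C)(=O)=O)cc2)c1`, 7850 nM
- compound 2, `CC(=O)Nc1ccc(S(=O)(=O)NNc2ccc(C)cc2)cc1`, 1170 nM
- compound 3, `CC(=O)Nc1ccc(S(=O)(=O)NNc2ccc(F)cc2)cc1`, 609 nM

All three were tested in an assay on HeLa cells for inhibition of Indoleamine 2,3-dioxygenase 1 (Homo sapiens), read by spectrophotometry, with a stated time of 24 h; on this read-out higher numbers stand for an effect only at larger amounts of compound and lower numbers for an effect already at smaller amounts. Compound 2 holds the second highest of the three numbers. Its nearest neighbour is compound 3, and the step of a 1.9-fold lower number from compound 2 to compound 3 (0.28 log units; within the scatter) is too small to count as a real change. Compound 1 lies further away: in this assay compound 1 gives 7850 nM, a higher number than compound 2 beyond the usual scatter, though the two structures differ in more than one place, so no single cause can be read from them.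

Compound 4, `CC(=O)Nc1ccc(S(=O)(=O)NNc2ccc(Cl)cc2)cc1`, has not yet been measured. It differs from compound 2 by chloro in place of methyl on an aromatic carbon. Among the compounds with values here, the only measured step that speaks to this change is the one from compound 2 to compound 3, where fluoro replaced the same methyl, and that step stayed within the scatter. A comparable small change is therefore expected here, if any, with no clear direction beyond the scatter: a 1.4-fold lower number from compound 2 to compound 4 (0.14 log units; within the scatter) is the estimated step. Compound 4 is expected to give about 850 nM, in the range from 300 nM to 2500 nM.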

Compound 4, half-maximal effective concentration: 142 nM
Compound 4: the middle estimate sits 6.0-fold (0.78 log units) above what was measured; the measured number lies below the stated range.
By their numbers in this assay, from the lowest: compound 4; then compounds 3 and 2 (each within the scatter of the next); then compound 1.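

The position para to a large group responds clearly to what sits there in this assay: chloro in place of methyl gives an 8.2-fold lower number from compound 2 to compound 4 (0.92 log units; beyond the scatter), whereas fluoro in place of the same methyl gave only a 1.9-fold lower number from compound 2 to compound 3 (0.28 log units; within the scatter). Exchanging one halogen for the other also matters, with a 4.3-fold lower number from compound 3 to compound 4 (0.63 log units; beyond the scatter), so chloro and fluoro cannot be treated as interchangeable at this position. Nothing measured here accounts for this difference.

As far as these compounds go, it remains open whether other groups at this position, such as bromo, methoxy or an amine, would give numbers closer to that of compound 4 or to that of compound 2. From the compounds shown here alone, it is also open whether chloro would bring a similar step on the core of compound 1.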